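This account rests on a few compounds, and the source may have more. Where it says the series, first, only, none or still open, it means among the compounds named here.

The three measured compounds share one core. In a functional assay for inhibition, read by spectrophotometry, with a stated time of 20 min, tested at 5 mg/mL (on this read-out higher numbers stand for a stronger effect at the one concentration tested and lower numbers for a weaker effect), compound 1 `CCC(C)C(C(=O)Nc1ccc(C(C)=O)cc1)N(C(=O)c1ccccc1)S(=O)(=O)c1ccc([N+](=O)[O-])cc1` gives 53.2%. Compound 2 `CC(=O)c1ccc(NC(=O)CN(C(=O)c2ccccc2)S(=O)(=O)c2ccccc2)cc1` gives 45.4%, and compound 3 `CC(=O)c1ccc(NC(=O)C(CC(C)C)N(C(=O)c2ccccc2)S(=O)(=O)c2ccccc2)cc1` gives 52.2%. Compound 3 thus stands second highest of the three numbers, yet its distance to compound 1 and its distance to compound 2 both fall within the scatter, so no real order among the three can be read from them.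

Compound 4 `CCC(C)C(C(=O)Nc1ccc(C(C)=O)cc1)N(C(=O)c1ccccc1)S(=O)(=O)c1ccccc1` has not yet been measured. It differs from compound 3 in one place: sec-butyl in place of isobutyl on a saturated chain carbon bound to an amide-type nitrogen and a carbonyl carbon. Within the data shown here, the only measured step at this same place is a number 6.8 percentage points higher from compound 2 to compound 3 (within the scatter), which stayed within the scatter even though a whole isobutyl chain was added where hydrogen had been. Exchanging one branched chain for another of the same size is a smaller change than that, so no shift beyond the scatter is expected. Compound 4 is therefore estimated to give about 52%, with a likely range from 42% to 62%. The expected step of a number 0.2 percentage points lower from compound 3 to compound 4 (within the scatter) should lie within the scatter.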

Compound 4, a percentage reported as inhibition, at one concentration (the size of the read-out at that concentration, not a potency): 16.8%
Compound 4: the middle estimate sits 35.2 percentage points above what was measured; the measured number lies below the stated range.
By their numbers in this assay, from the lowest: compound 4; then compounds 2, 3 and 1 (each within the scatter of the next).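

In this assay, isobutyl and sec-butyl hold the same atoms joined differently, yet that exchange gives a number 35.4 percentage points lower from compound 3 to compound 4 (beyond the scatter), so at this saturated chain carbon bound to an amide-type nitrogen and a carbonyl carbon, how the chain is joined matters and not only its atom count. Sec-butyl in place of hydrogen at this place gives a number 28.6 percentage points lower from compound 2 to compound 4 (beyond the scatter), while isobutyl in place of hydrogen gives a number 6.8 percentage points higher from compound 2 to compound 3 (within the scatter), so the two chains part ways here. Sec-butyl alone does not set the low number, since hydrogen in place of nitro on an aromatic carbon gives a number 36.4 percentage points lower from compound 1 to compound 4 (beyond the scatter), which shows that the effect of this chain depends on what the aromatic carbon carries.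

Nothing given here explains these drops.

As far as these compounds go, it remains open whether nitro would change the number for the isobutyl compound, and whether an amine in place of nitro would act as nitro does alongside sec-butyl.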